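A few compounds are considered here, and "the series" means these few. Any claim that something is new, unique, unknown or untested is made for them only; others in the source may bear on it.

Of the compounds shown here, three sharing one core have so far been measured in a functional assay for inhibition, with Homo sapiens as the target; a lower number here means a stronger inhibitor, a higher number a weaker inhibitor. Compound 1 `CCc1cccc(Nc2nccc(-c3ccco3)n2)c1` gives 9700 nM. Compound 2 `c1ccc(Nc2nccc(-c3cccs3)n2)cc1` gives 31700 nM in this assay. Compound 3 `CC1CCN(c2ccc(Nc3nccc(-c4ccco4)n3)cc2)CC1` gives 1800 nM, the lowest of the three numbers; the nearest to it is compound 1 and the furthest compound 2, and both gaps lie beyond the scatter of repeated measurements, so compound 3 stands as the strongest inhibitor among those measured.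

The next compound, compound 4 `c1ccc(Nc2nccc(-c3ccco3)n2)cc1`, has not yet been measured. It differs from compound 3 in one place: hydrogen in place of 4-methylpiperidin-1-yl on an aromatic carbon. Within the data shown here, no step between two measured compounds isolates this change, so what can be said rests on compounds 1 and 2, which both carry a hydrogen rather than the 4-methylpiperidin-1-yl group at this position and both give higher numbers than compound 3.

On that ground the step of an 8.3-fold higher number from compound 3 to compound 4 (0.92 log units; beyond the scatter) is expected to weaken inhibition, a move in the upward direction and beyond the usual scatter. Compound 4 is therefore estimated at 15000 nM, with a likely range from 5000 nM to 45000 nM.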

Compound 4, half-maximal inhibitory concentration: 32000 nM
The estimate for compound 4 lay 2.1-fold (0.33 log units) below the measured number, within the range that was stated.
By their numbers in this assay, from the lowest: compound 3; then compound 1; then compounds 2 and 4 (each within the scatter of the next).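

Hydrogen in place of 4-methylpiperidin-1-yl, para to a large group, can now be read directly: this assay shows an 18-fold higher number from compound 3 to compound 4 (1.25 log units; beyond the scatter) as a large step, so the group is tied to a clear gain in inhibition against the unsubstituted compound 4. A smaller substituent also counts, since hydrogen in place of ethyl gives a 3.3-fold higher number from compound 1 to compound 4 (0.52 log units; beyond the scatter) as a modest step, and in both pairs the compound with hydrogen has the higher number. The ring on the other side of the shared core does not separate the two unsubstituted compounds, as a 1.0-fold higher number from compound 2 to compound 4 (0.00 log units; within the scatter) lies within the scatter and furan-2-yl and thiophen-2-yl cannot be told apart in this pair.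

The compounds shown leave open whether the gain belongs to the ring nitrogen, the six-membered ring or its methyl group, which a plain piperidine, a morpholine or a simple dimethylamino group on the same carbon could help to separate. Nothing available gives a reason for the size of these steps.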